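The compounds below may be only part of what the source reports. "The series", "measured", "known", "first", "only" and "open" are said of these compounds alone.

Compound 1 (`CC(C)CN1C(=O)/C(=C/c2ccc(Cl)cc2)S/C1=N\c1ccccc1`), compound 2 (`CC(C)CN1C(=O)/C(=C/c2ccc([N+](=O)[O-])cc2)S/C1=N\c1ccccc1`) and compound 3 (`Cc1ccc(/C=C2\S/C(=N\c3ccccc3)N(CC(C)C)C2=O)cc1`) are close relatives that share a core. In an ADME assay on HepG2 cells (Homo sapiens) for cytotoxicity, read by MTT assay, with a stated time of 48 h (a lower number here means a stronger inhibitor, a higher number a weaker inhibitor), compound 3 has no single number: its entry reads "not determined" (no result reported) and the entry of compound 1 also reads "not determined" (no result reported) with no result behind it. Compound 2 gives > 100000 nM in this assay and this is a limit of the assay, not a number.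

Compound 4 (`CCc1ccc(/C=C2\S/C(=N\c3ccccc3)N(CC(C)C)C2=O)cc1`) differs from compound 3 in one place (methyl in place of hydrogen on a saturated chain carbon bound to an aromatic carbon): methyl in place of hydrogen on a saturated chain carbon bound to an aromatic carbon, which turns 4-methylphenyl into 4-ethylphenyl. Within the data shown here, no measured pair in this set shows what such a change does in this assay so no step beyond the usual scatter is expected, in either direction. Among the measured compounds shown here, the only guide is compound 2 with its limit of > 100000 nM and a limit is therefore the likeliest outcome for compound 4 too. For compound 4 the expected value is 100000 nM with an estimated range from 40000 nM to 200000 nM in this test.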

Compound 4, half-maximal inhibitory concentration: 84700 nM
The estimate for compound 4 lay 1.2-fold (0.07 log units) above the measured number, and the stated range covers the measured number.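

In this assay compound 4 gives 84700 nM, the only actual number among the compounds shown, so this family now has one measured point. Ethyl in place of nitro on an aromatic carbon gives an at least 1.1-fold lower number from compound 2 to compound 4 (0.07 log units; that floor lies within the scatter), so this change cannot be said to move the result beyond the scatter, and its true size remains unknown. Compound 2 remains a limit, not a number, and so fixes only one end of this comparison: the limit of > 100000 nM in this assay, at which 1 of the 4 values shown sits.

The step from methyl to ethyl cannot be read, since compound 3 has no number to start from. On these data alone, whether a longer chain such as propyl, or a carboxylic acid, on that aromatic ring would shift the number beyond the scatter stays open.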